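Replacement of the 1-((dimethylamino)methyl)-1-methylethyl group on the shared core of compound 1

The compounds below may be only part of what the source reports. "The series", "measured", "known", "first", "only" and "open" are said of these compounds alone.

Two compounds of this series have numbers in an assay on HEK293 cells for displacement of a labelled ligand from B1 bradykinin receptor (Homo sapiens), read by scintillation counting; on this read-out lower numbers stand for stronger inhibition and higher numbers for weaker inhibition. Compound 1 `COc1cc(C)c(S(=O)(=O)N(C)CCOCC(=O)N2CCC(C(C)(C)CN(C)C)CC2)c(C)c1` gives 10 nM in this assay, the highest of the two numbers shown. Compound 2 `CCN1CCC(N2CCN(C(=O)COCCN(C)S(=O)(=O)c3c(C)cc(OC)cc3C)CC2)CC1` gives 0.2 nM in this assay, a gap to compound 1 that lies beyond the scatter and shows that numbers far below that of compound 1 are reachable within this series.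

Compound 3 `COc1cc(C)c(S(=O)(=O)N(C)CCOCC(=O)N2CCC(C3CCN(C(C)C)CC3)CC2)c(C)c1` is not yet measured in this assay. It differs from compound 1 in one place: 1-isopropylpiperidin-4-yl in place of 1-((dimethylamino)methyl)-1-methylethyl on a saturated ring carbon. Within the data shown here, nothing is known about how such a change plays out, as no measured pair differs in this way alone; the expectation below therefore rests on compound 1 and on the low number of compound 2 only.

For compound 3 a moderate improvement over compound 1 is expected, a step of a 5.0-fold lower number from compound 1 to compound 3 (0.70 log units; beyond the scatter) in this assay. This expected step falls short of the gap to compound 2, whose number is 0.2 nM. The estimate for compound 3 in this assay is 2 nM, with a range from 0.4 nM to 10 nM.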

Compound 3, inhibition constant: 0.4 nM
Estimate against measurement, compound 3: 5.0-fold (0.70 log units) above; measured number inside the range.
By their numbers in this assay, from the lowest: compounds 2 and 3 (each within the scatter of the next); then compound 1.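

In this assay, among these compounds, 1-isopropylpiperidin-4-yl in place of 1-((dimethylamino)methyl)-1-methylethyl gives a 25-fold lower number from compound 1 to compound 3 (1.40 log units; beyond the scatter), the first step that can be read at a single position. It shows that the group on this saturated ring carbon can by itself shift the number well beyond the scatter while the rest of compound 1 stays unchanged, and that an open-chain group without a ring is not needed here, since the entering group carries a six-membered non-aromatic ring and has the same counts of hydrogen-bond donors and acceptors as the group it replaces. No measurement here accounts for the size of this step, and the pair cannot separate the added ring from the larger heavy-atom count.

As far as these compounds go, it remains open how much of the step depends on the isopropyl group on the ring nitrogen, which a comparison with 1-methylpiperidin-4-yl or the unsubstituted piperidin-4-yl would address. From the compounds shown here alone, the role of the ring nitrogen itself also remains open, and a tetrahydropyran-4-yl group, with oxygen in its place, would bear on that question.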